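Methyl to hydrogen on the shared core: lipophilicity notes

This account rests on a few compounds, and the source may have more. Where it says the series, first, only, none or still open, it means among the compounds named here.

Compound 1 `Cc1cccc2nc(C#N)c([N+](=O)[O-])n12` is the reference point of this set. Among the measured compounds shown here, in a physicochemical assay for lipophilicity, measured as octanol-water partition (a higher number here means a more lipophilic compound, a lower number a more polar compound), compound 1 gives 1.08, the lowest of the three numbers measured so far. Compound 2 `Cc1cccc2nc(NC3CCCCC3)c([N+](=O)[O-])n12` differs from it in the group on the core; the difference between the two cores of compound 1 and compound 2 is not broken down here. In this assay compound 2 gives 1.5. Compound 3 `O=[N+]([O-])c1c(NC2CCCCC2)nc2ccccn12` is obtained from compound 2 by hydrogen in place of methyl on an aromatic carbon. In this assay compound 3 gives 1.5, so that the step of no change at the digits printed from compound 2 to compound 3 (within the scatter).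

Compound 4 `N#Cc1nc2ccccn2c1[N+](=O)[O-]` is not yet measured. It stands to compound 1 as compound 3 stands to compound 2: the change is hydrogen in place of methyl on an aromatic carbon, the same change at the same place, which occurs twice among these compounds. For the measured compounds named here, the only measured instance of it, no change at the digits printed from compound 2 to compound 3 (within the scatter), is the sole basis for what follows. The step is therefore expected to be small, a number 0.08 log units lower from compound 1 to compound 4 (within the scatter). For compound 4 the expected value in this assay is 1, estimated to lie between 0.6 and 1.4; the support is one pair only, and compound 1 and compound 2 do not share the same group on the core.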

Compound 4, partition coefficient: 0.692
For compound 4 the middle estimate is 0.31 log units above the measured one; measured number inside the range.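

In this assay hydrogen in place of methyl on an aromatic carbon gives a number 0.39 log units lower from compound 1 to compound 4 (beyond the scatter) in one pair, while the same change gives no change at the digits printed from compound 2 to compound 3 (within the scatter) in the other pair, which carries a different group on the core. The change therefore does not carry over as one fixed step between these two pairs: the step lies beyond the scatter in the first and within it in the second. Two pairs give no general rule for this change on other cores, and nothing shown here bears on what separates the two results.

Open, going by these compounds, is the size of the step when the group on the core is neither the nitrile of compound 1 nor the group carried by compound 2, for example a carboxylic acid or a longer chain. Also open, on these data alone, is how this assay responds when the methyl gives way to something other than hydrogen, such as an ethyl group or a primary amine.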